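A few compounds are considered here, and "the series" means these few. Any claim that something is new, unique, unknown or untested is made for them only; others in the source may bear on it.

In a functional assay on NCI-H522 cells (Homo sapiens) for cytotoxicity, with a stated time of 3 days (a lower number here means a stronger inhibitor, a higher number a weaker inhibitor), compound 1 `C=Cc1nc2ccccc2n1C` gives 2340 nM and compound 3 `C#Cc1nc2ccccc2n1C` gives 8140 nM, the higher of the two actual numbers. The gap is a 3.5-fold higher number from compound 1 to compound 3 (0.54 log units; beyond the scatter). Compound 2 `Cn1cnc2ccccc21`, with hydrogen at the same place, reads > 40000 nM, which is a limit of the assay. Compound 4 `Cn1c(Br)nc2ccccc21` brings (bromo in place of ethynyl on an aromatic carbon), with bromo in place of ethynyl on an aromatic carbon. Among the compounds with values here, no measured step involves bromo. The nearest guides are an at least 17-fold higher number from compound 1 to compound 2 (1.23 log units; beyond the scatter) and an at least 4.9-fold lower number from compound 2 to compound 3 (0.69 log units; beyond the scatter), so a group at this place can matter. Starting from compound 3 at 8140 nM, a modest move to a higher number is expected, giving an estimated 2.2-fold higher number from compound 3 to compound 4 (0.34 log units; beyond the scatter). For compound 4 the estimated value is 18000 nM, with an expected range from 6000 nM to 40000 nM.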

Compound 4, half-maximal inhibitory concentration: > 40000 nM
Compound 4 ended at the assay's limit; the forecaster's own chance of this, stated with the estimate: 30%; middle value at least 2.2-fold (0.34 log units) from the limit.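

In this assay compound 4 gives > 40000 nM, which is a limit of the assay and not a number. Bromo at this place, between two ring nitrogen atoms, does not keep the readable activity of ethynyl or vinyl: an at least 4.9-fold higher number from compound 3 to compound 4 (0.69 log units; beyond the scatter) and an at least 17-fold higher number from compound 1 to compound 4 (1.23 log units; beyond the scatter). The step between compound 2 and compound 4 cannot be read, so bromo and hydrogen cannot be ranked: the limit of > 40000 nM in this assay, at which 2 of the 4 values shown sit.

Among the compounds shown, only vinyl and ethynyl give a readable number here. From the compounds shown here alone, how an ethyl group, a longer chain or an amine would read at this place stays open.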